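Dichloroacetamide biphenyls: removing the amino group

This account rests on a few compounds, and the source may have more. Where it says the series, first, only, none or still open, it means among the compounds named here.

Working notes on a small set of dichloroacetamides on a biphenyl-type core, read in a functional assay on NCI-H460 cells (Homo sapiens) for cytotoxicity, read by MTT assay, with a stated time of 68 h; on this read-out lower numbers stand for stronger inhibition and higher numbers for weaker inhibition. Compound 1 `Nc1cccc(-c2cccc(NC(=O)C(Cl)Cl)c2)c1` returns in this assay only a limit, > 50000 nM, not a number; among the values shown it sits at the limit of > 50000 nM in this assay, at which 1 of the 3 values shown sits. Compound 2 `CCOc1cccc(-c2cc(NC(=O)C(Cl)Cl)cc(-c3cccc(OCC)c3)c2)c1` gives 4950 nM in this assay, and compound 3 `CCOc1ccccc1-c1cc(NC(=O)C(Cl)Cl)cc(-c2ccccc2OCC)c1` gives 5090 nM; these two lie within the scatter of each other. Compound 4 `O=C(Nc1cccc(-c2ccccc2)c1)C(Cl)Cl` is not yet measured; against compound 1 the change is hydrogen in place of amino on an aromatic carbon. Among the measured compounds shown here, no measured pair carries this change, so its size is unknown, and the step is expected to be an at least 1.2-fold lower number from compound 1 to compound 4 (0.09 log units; that floor lies within the scatter), modest at most and not clearly beyond the scatter. Compound 4 is therefore estimated at 40000 nM, with a range from 10000 nM to 150000 nM, and a fair chance that only a limit is returned.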

Compound 4, half-maximal inhibitory concentration: 20200 nM
Beside the measured number, compound 4's estimate is 2.0-fold (0.30 log units) above it; the measured number falls inside the stated range.
By their numbers in this assay, from the lowest: compounds 2 and 3 (each within the scatter of the next); then compound 4. At a limit, above all of these: compound 1.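

Among the compounds shown here, the first single-place comparison falls on the aromatic carbon meta to a large group: in this assay, hydrogen in place of amino gives an at least 2.4-fold lower number from compound 1 to compound 4 (0.39 log units; beyond the scatter). With amino gone, compound 4 returns a number rather than a limit. Compound 1 stands only at a limit, so this step has a floor but no known upper size: the limit of > 50000 nM in this assay, at which 1 of the 4 values shown sits.

Going by these compounds, how a methoxy group, a carboxylic acid or a longer chain at this place would read remains open. For the compounds shown here, compound 2 and compound 3 differ from compound 4 in more than one place, so no steps to them can be read.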